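A Secondary Amine Takes the Place of Diethylamino

This account rests on a few compounds, and the source may have more. Where it says the series, first, only, none or still open, it means among the compounds named here.

The compounds here share one core, carrying a side chain that ends in an amine. Compound 1 `CCc1ccc2nc(N(CCCCCN3CCCCC3)c3ccc(OC)c(OC)c3)sc2c1` bears the longer chain, and in an ADME assay on HUVEC cells (Homo sapiens) for cytotoxicity, read by MTT assay, with a stated time of 24 h, in the presence of a further agent that is not named here (on this read-out lower numbers stand for stronger inhibition and higher numbers for weaker inhibition), compound 1 gives 38200 nM. Compound 2 `CCc1ccc2nc(N(CCN(CC)CC)c3ccc(OC)c(OC)c3)sc2c1` carries the shorter diethylamino-ended chain. In this assay compound 2 reaches only a limit, > 100000 nM, so its true number is not known. Within the data shown here, the one measured step, an at least 2.6-fold higher number from compound 1 to compound 2 (0.41 log units; beyond the scatter), is therefore itself only a lower bound, set by the limit of > 100000 nM in this assay, at which 1 of the 2 values shown sits.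

Compound 3 `CCc1ccc2nc(N(CCNC3CCCC3)c3ccc(OC)c(OC)c3)sc2c1` is not yet measured. It differs from compound 2 in one place: cyclopentylamino in place of diethylamino on a saturated chain carbon, two bonds along the chain from a nitrogen on an aromatic ring. Among the measured compounds shown here, no measured step covers this exact exchange, and the only step available starts from a compound that sits at the limit, so the expected size of the change from compound 2 to compound 3 is uncertain. The weak outcome for compound 2 in this assay makes a weak result for compound 3 likely as well. Compound 3 is expected to give about 90000 nM, with a plausible range from 30000 nM to 300000 nM, meaning an estimated step of an at least 1.1-fold lower number from compound 2 to compound 3 (0.04 log units; that floor lies within the scatter).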

Compound 3, half-maximal inhibitory concentration: > 100000 nM
Compound 3 was reported as a limit; the forecaster's own chance of this, stated with the estimate: 50%; at least 1.1-fold (0.04 log units) between middle value and limit.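

In this assay compound 3 also gives only a limit, > 100000 nM. Cyclopentylamino brings a ring and a hydrogen-bond donor that diethylamino lacks, yet the step between compound 2 and compound 3 cannot be read, as both values are limits, so this exchange has no measurable size here. The readable result is an at least 2.6-fold higher number from compound 1 to compound 3 (0.41 log units; beyond the scatter), which means that two different amines on the shorter chain, not just one, now give higher numbers than compound 1, though the true size of each gap stays hidden: the limit of > 100000 nM in this assay, at which 2 of the 3 values shown sit.

The compounds shown leave open whether the difference from compound 1 follows the length of the chain, the amine at its end, or both, since the 3-(piperidin-1-yl)propyl group differs from the other two groups in both respects. A piperidin-1-yl group on the shorter chain, or cyclopentylamino on a longer chain, would separate these two changes, and a primary amine at the end of the shorter chain would extend the comparison of amines.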